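The source may hold more compounds than are shown below. What is called first, only, known or untested is meant among the compounds shown, and "the series" means these compounds.

Measured compounds:
- compound 1, `COc1ccc(N2CCN(C(=S)SCc3ccc(C(=O)Nc4ccccc4N)cc3)CC2)cc1`, 28.1%
- compound 2, `Nc1ccccc1NC(=O)c1ccc(CSC(=S)N2CCCc3ccccc32)cc1`, 26.5%
- compound 3, `CC1CCN(C(=S)SCc2ccc(C(=O)Nc3ccccc3N)cc2)CC1`, 32.7%

In a functional assay on A-375 cells (Homo sapiens) for antiproliferative activity, read by CCK-8 assay, with a stated time of 72 h, tested at 2 uM (on this read-out lower numbers stand for a weaker effect and higher numbers for a stronger effect at the one concentration tested), compound 1 gives 28.1%. The nearest of the other two numbers is that of compound 2, the furthest that of compound 3, and compound 1 stands within the scatter of both, so the three measured compounds cannot be told apart on this read-out.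

Among the measured compounds shown here, the one step between measured compounds that differ in a single place is a number 6.2 percentage points higher from compound 2 to compound 3 (within the scatter), and it falls within the scatter.

Compound 4, `Nc1ccccc1NC(=O)c1ccc(CSC(=S)N2CCN(Cc3cccnc3)CC2)cc1`, has not been measured. It differs from compound 1 in one place: (pyridin-3-yl)methyl in place of 4-methoxyphenyl on an amine nitrogen in a ring. For the measured compounds named here, no measured pair tests a change at this ring nitrogen; the step from compound 2 to compound 3 is the only one that alters the amine side of the thiocarbonyl, and it stayed within the scatter. Given that, compound 4 is expected to sit close to compound 1, with a number 1.9 percentage points higher from compound 1 to compound 4 (within the scatter) as the expected step. Compound 4 is therefore estimated at 30%, with a range from 18% to 42%.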

Compound 4, a percentage reported as inhibition, at one concentration (the size of the read-out at that concentration, not a potency): 31.5%
Compound 4: the middle estimate sits 1.5 percentage points below what was measured, and the stated range covers the measured number.
By their numbers in this assay, from the lowest: compounds 2, 1, 4 and 3 (each within the scatter of the next).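

In this assay, among the compounds shown here, the ring nitrogen of the six-membered non-aromatic ring with 2 nitrogen, which carries 4-methoxyphenyl in compound 1, was tested for the first time with another group, and (pyridin-3-yl)methyl gives a number 3.4 percentage points higher from compound 1 to compound 4 (within the scatter) on this read-out. The result shows that this exchange, from one six-membered aromatic ring of carbon only to one with 1 hetero atom, and with a different link to the amine nitrogen, leaves the two compounds indistinguishable at the one concentration tested. Nothing available here bears on why this is so.

The ring and its link change together in this one step, so a benzyl group on this nitrogen would be needed to tell them apart. The compounds shown also leave open how a carboxylic acid or a longer alkyl chain at this position would read out.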